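The compounds below may be only part of what the source reports. "The series", "measured", "known", "first", "only" and "open" are said of these compounds alone.

Compound 2 `Cc1cc(O)c(C2=NN(c3ccc(S(N)(=O)=O)cc3)C(c3ccccc3Cl)C2)cc1Cl` and compound 1 `Cc1cc(O)c(C2=NN(c3ccc(S(N)(=O)=O)cc3)C(c3ccccc3O)C2)cc1Cl` share one core and differ at a single aromatic carbon. In a functional assay on ACHN cells (Homo sapiens) for antiproliferative activity, with a stated time of 48 h (a higher number here means a weaker inhibitor of growth, a lower number a stronger inhibitor of growth), compound 1 gives 11200 nM, and compound 2 gives 11000 nM. Going by the values given here, the only measured step, a 1.0-fold lower number from compound 1 to compound 2 (0.01 log units; within the scatter), swaps chloro for hydroxy, and the two numbers sit within the scatter of each other, so neither compound can be called the stronger inhibitor of growth. Compound 3 `Cc1cc(O)c(C2=NN(c3ccc(S(N)(=O)=O)cc3)C(/C=C/c3ccccc3)C2)cc1Cl` is the next variation: 2-phenylethenyl in place of 2-chlorophenyl on a saturated ring carbon. Among the compounds with values here, no measured step bears directly on this change; the one step in hand touched only a substituent on the aromatic ring and left the ring itself in place, whereas here the whole 2-chlorophenyl gives way to a 2-phenylethenyl. With nothing in the data pointing in either direction, the expectation is a step no larger than the scatter, no change at the digits printed from compound 2 to compound 3 (within the scatter), and the range around it is kept wide to allow for an unfamiliar change. Compound 3 is therefore estimated at 11000 nM, within 3000 nM to 40000 nM.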

Compound 3, concentration for total growth inhibition: 21900 nM
Compound 3: middle estimate off by 2.0-fold (0.30 log units), on the low side; the measured number falls inside the stated range.
By their numbers in this assay, from the lowest: compounds 2, 1 and 3 (each within the scatter of the next).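

At this saturated ring carbon, the whole aryl group can be replaced by 2-phenylethenyl, which brings 1 double bond outside aromatic rings, and in this assay both steps stay within the scatter: a 2.0-fold higher number from compound 2 to compound 3 (0.30 log units; within the scatter) and a 2.0-fold higher number from compound 1 to compound 3 (0.29 log units; within the scatter). The earlier pair showed only that a substituent on the ring attached to this carbon could be exchanged, whereas compound 3 shows the same lack of a clear difference for a larger replacement of the group itself, so compounds 1, 2 and 3 cannot be separated as inhibitors of growth here. Nothing measured alongside these numbers offers an explanation for this result.

From the compounds shown here alone, all three groups at this carbon contain a six-membered aromatic ring of carbon only, so it remains open whether a plain methyl, a longer alkyl chain, an amine or a carboxylic acid would also leave the number within the scatter. The 4-sulfamoylphenyl and 5-chloro-2-hydroxy-4-methylphenyl groups are the same in all three compounds, so these data say nothing about how changes to either would register in this assay.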